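The source may hold more compounds than are shown below. What is called first, only, known or untested is meant among the compounds shown, and "the series" means these compounds.

Measured compounds:
compound 1 `O=C(O)c1ccc(-c2cnc(C(=O)CCCCCCc3ccccc3)o2)cc1` – 60 nM
compound 2 `O=C(CCCCCCc1ccccc1)c1ncc(-c2ccc(F)cc2)o1` – 62 nM

Within the data shown here, in an assay (Rattus norvegicus) for inhibition of Fatty-acid amide hydrolase 1 (Homo sapiens) (on this read-out lower numbers stand for stronger inhibition and higher numbers for weaker inhibition), compound 2 gives 62 nM and compound 1 gives 60 nM; the two numbers lie within the scatter of each other, and the only step in the set so far, a 1.0-fold higher number from compound 1 to compound 2 (0.01 log units; within the scatter), shows that swapping carboxy for fluoro on the aromatic carbon para to the large group left the read-out essentially unchanged.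

Compound 3 `NC(=O)c1ccc(-c2cnc(C(=O)CCCCCCc3ccccc3)o2)cc1` is not yet measured. Its change from compound 2 is carbamoyl in place of fluoro on an aromatic carbon. Among the measured compounds shown here, the one step that bears on it is the same exchange of para groups between compound 1 and compound 2, which stayed within the scatter. On that basis compound 3 is expected to give a step of a 1.0-fold lower number from compound 2 to compound 3 (0.01 log units; within the scatter), with no change beyond the scatter. The estimate for compound 3 is 60 nM, ranging from 25 nM to 150 nM.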

Compound 3, inhibition constant: 10 nM
Estimate against measurement, compound 3: 6.0-fold (0.78 log units) above; measured number below the stated range.
By their numbers in this assay, from the lowest: compound 3; then compounds 1 and 2 (each within the scatter of the next).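

At this position, para to a large group, the read-out in this assay proves sensitive to the group carried: the carboxy and fluoro compounds lay within the scatter of each other, whereas carbamoyl in place of fluoro gives a 6.2-fold lower number from compound 2 to compound 3 (0.79 log units; beyond the scatter) as the step. Carbamoyl also separates from carboxy, and amino in place of hydroxy on the same carbonyl carbon gives a 6.0-fold lower number from compound 1 to compound 3 (0.78 log units; beyond the scatter) as the step, so a change of one atom within the group is enough to move the number beyond the scatter. Nothing available accounts for this difference.

Still open, on these data alone, is whether the amide hydrogen matters, which methylcarbamoyl, dimethylcarbamoyl or a nitrile at this position could test. Also open, as far as these compounds go, is whether the same step holds on a shorter or longer chain than the phenylhexyl chain shared by these compounds.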